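Lengthening the Amine Substituent from Propyl to Butyl

The source may report more compounds than this note shows. Statements on the series, on what has been measured and on what is new or still open speak of the compounds shown alone.

In an assay on isolated protein for inhibition of Amine oxidase [flavin-containing] A (Homo sapiens), read by fluorescence and Amplex Red, with a stated time of 15 min (a higher number here means a weaker inhibitor, a lower number a stronger inhibitor), compound 1 `C#CCNCc1cn(-c2cc(NC(=S)NCC)ncn2)cn1` gives 4330 nM. Compound 2 `C#CCN(CCC)Cc1cn(-c2cc(NC(=S)NCC)ncn2)cn1` reaches only the limit > 50000 nM in this assay. For the measured compounds named here, the single measured step, an at least 11-fold higher number from compound 1 to compound 2 (1.06 log units; beyond the scatter), ends at the limit of > 50000 nM in this assay, at which 1 of the 2 values shown sits. Compound 3 `C#CCN(CCCC)Cc1cn(-c2cc(NC(=S)NCC)ncn2)cn1` differs from compound 2 by methyl in place of hydrogen on a saturated chain carbon, three bonds along the chain from an amine nitrogen. With compound 2 already at the limit, the measured step fixes no size or direction for the step to compound 3, and compound 3 is expected to stay at the limit, the estimated step being a number no higher from compound 2 to compound 3 (the limit leaves the size open). For compound 3 the estimate is 50000 nM, with a range from 20000 nM to 150000 nM.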

Compound 3, half-maximal inhibitory concentration: > 50000 nM
Compound 3: only a limit was reported (the forecaster's own chance of this, stated with the estimate: 85%); the middle value sits exactly at the limit.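

Butyl in place of hydrogen on the amine nitrogen gives an at least 11-fold higher number from compound 1 to compound 3 (1.06 log units; beyond the scatter), so a second chain length on this nitrogen shows the same large loss as propyl. In this assay compound 3 gives > 50000 nM, which is a limit and not a number. The step from propyl to butyl cannot be read, as compound 2 and compound 3 stand at the same limit: the limit of > 50000 nM in this assay, at which 2 of the 3 values shown sit.

The compounds shown leave open whether a shorter group on this nitrogen, such as methyl or ethyl, keeps a measurable value. They also leave open whether a hydroxyl on the chain would do so.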